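A few compounds are considered here, and "the series" means these few. Any claim that something is new, unique, unknown or untested is made for them only; others in the source may bear on it.

Measured compounds:
compound 1 `COc1ccc(C(C)NC(=O)/N=C(\N)NCCCc2sc(N)nc2C)cc1`: 37.2 nM
compound 2 `Cc1nc(N)sc1CCCN/C(N)=N/C(=O)NC(C)c1ccc(Br)cc1`: 30.2 nM

Both compounds were tested in an assay on membranes from Sf9 cells for displacement of a labelled ligand from histamine H2 receptor (Homo sapiens), read by scintillation counting, with a stated time of 60 min; on this read-out lower numbers stand for stronger inhibition and higher numbers for weaker inhibition. Among the measured compounds shown here, compound 2 shows the lower of the two numbers in this assay, but its only neighbour is compound 1, and the step of a 1.2-fold lower number from compound 1 to compound 2 (0.09 log units; within the scatter) lies within the scatter, so the two values cannot be told apart.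

The unmeasured compound 3 `Cc1nc(N)sc1CCCN/C(N)=N/C(=O)NC(C)c1ccccc1F` differs from compound 2 in one place: 2-fluorophenyl in place of 4-bromophenyl on a saturated chain carbon bound to an amide-type nitrogen and a saturated chain carbon. For the measured compounds named here, only one measured step bears on this change, and only loosely: a 1.2-fold lower number from compound 1 to compound 2 (0.09 log units; within the scatter) exchanged one group for another on the same aromatic ring while leaving the number essentially unchanged. In compound 3 the whole aromatic group is exchanged, from 4-bromophenyl to 2-fluorophenyl, which is a different kind of change from the one measured, so the guidance is thin.

With nothing in hand pointing either way, the step from compound 2 to compound 3 in this assay is expected to be a 1.2-fold higher number from compound 2 to compound 3 (0.06 log units; within the scatter), that is, none beyond the scatter. Compound 3 is therefore estimated at 35 nM, with a range from 12 nM to 110 nM.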

Compound 3, inhibition constant: 28.8 nM
Estimate against measurement, compound 3: 1.2-fold (0.08 log units) above, within the range that was stated.
By their numbers in this assay, from the lowest: compounds 3, 2 and 1 (each within the scatter of the next).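

Among the compounds shown here, at this place, on the saturated chain carbon bound to an amide-type nitrogen and a saturated chain carbon, the earlier pair showed only one group on the aromatic ring exchanged for another, with the ring's substitution pattern kept. Compound 3 goes further, and in this assay replacing 4-bromophenyl with 2-fluorophenyl gives a 1.0-fold lower number from compound 2 to compound 3 (0.02 log units; within the scatter) while replacing 4-methoxyphenyl with 2-fluorophenyl gives a 1.3-fold lower number from compound 1 to compound 3 (0.11 log units; within the scatter) so the read-out separates none of these three aromatic groups, even though the substituent differs in both its identity and its printed ring number. No measurement shown here offers an explanation for this sameness.

These three compounds all keep a substituted phenyl group at this place, so they leave open whether the read-out would stay this flat with a different kind of group there, such as a cyclohexyl ring or a phenyl ring carrying a carboxylic acid. Also open, on these data alone, is whether a 2-bromophenyl or 4-fluorophenyl group would fall in line with these compounds, which would separate the effect of the halogen from that of its place on the ring.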